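A Furan-3-yl for Pyridin-3-yl Swap on a Shared Core

This account rests on a few compounds, and the source may have more. Where it says the series, first, only, none or still open, it means among the compounds named here.

Compound 1 `O=C(c1ccc2c(c1)OCCO2)C1CCN(Cc2coc(-c3cccc(F)c3)n2)CC1` and compound 2 `O=C(c1ccc2c(c1)OCCO2)C1CCN(Cc2coc(-c3cccnc3)n2)CC1` share one core and differ only in the aromatic group attached to it. In an ADME assay on HEK293 cells (Homo sapiens) for cytotoxicity, read by MTT assay, with a stated time of 36 h (on this read-out lower numbers stand for stronger inhibition and higher numbers for weaker inhibition), compound 1 gives > 150 ug/mL, which is a limit of the assay and not a number. Compound 2 gives > 150 ug/mL in this assay, again a limit rather than a number. The step that the two limits leave unreadable from compound 1 to compound 2 therefore cannot be read, and compound 2 stands only at a limit, with no numerical value of its own; this is the limit of > 150 ug/mL in this assay, at which 2 of the 2 values shown sit, so every value shown is a limit.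

Compound 3 `O=C(c1ccc2c(c1)OCCO2)C1CCN(Cc2coc(-c3ccoc3)n2)CC1` is the next member of the series. Relative to compound 2 it carries furan-3-yl in place of pyridin-3-yl on an aromatic carbon. For the measured compounds named here, the only measured step that bears on this change is a step that the two limits leave unreadable from compound 1 to compound 2, whose size cannot be read, so no direction beyond the scatter can be inferred from it, and the two limits point towards compound 3 also sitting at the limit. The estimate for compound 3 in this assay is 180 ug/mL with a range from 90 ug/mL to 350 ug/mL. This corresponds to an expected step that the limit leaves unreadable from compound 2 to compound 3, most likely again unreadable against the limit.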

Compound 3, half-maximal inhibitory concentration: > 150 ug/mL
Compound 3: no number, only a limit; the forecaster's own chance of this, stated with the estimate: 85%; the middle value lies beyond the limit too.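

For the compounds shown here, compound 3, like compound 1 and compound 2, gives only a limit of the assay and not a number in this assay, so no step among the three can be read. All values shown stand at that one limit: the limit of > 150 ug/mL in this assay, at which 3 of the 3 values shown sit.

The compounds shown leave open whether 3-fluorophenyl, pyridin-3-yl and furan-3-yl differ at all in this assay, and at what concentration any of the three compounds would reach half-maximal inhibition.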